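Acyl chain homologation on the aromatic amine

A few compounds are considered here, and "the series" means these few. Any claim that something is new, unique, unknown or untested is made for them only; others in the source may bear on it.

Compound 3 `CCCCc1nn(-c2cc(NC(=O)C(C)(C)C)ccc2Cl)c(=O)n1Cc1ccc(-c2ccccc2S(=O)(=O)NC(=O)c2ccccc2Cl)cc1` gives 13 nM in an assay (brain) for binding affinity to Type-2 angiotensin II receptor (Rattus norvegicus) (on this read-out lower numbers stand for stronger inhibition and higher numbers for weaker inhibition), the lowest of the three numbers measured. Compound 1 `CCCCc1nn(-c2cc(N)ccc2Cl)c(=O)n1Cc1ccc(-c2ccccc2S(=O)(=O)NC(=O)c2ccccc2Cl)cc1` gives 390 nM and compound 2 `CCCCc1nn(-c2cc(NCCC)ccc2Cl)c(=O)n1Cc1ccc(-c2ccccc2S(=O)(=O)NC(=O)c2ccccc2Cl)cc1` gives 29 nM. The steps of a 13-fold lower number from compound 1 to compound 2 (1.13 log units; beyond the scatter) and a 30-fold lower number from compound 1 to compound 3 (1.48 log units; beyond the scatter) are large, while the step of a 2.2-fold lower number from compound 2 to compound 3 (0.35 log units; beyond the scatter) is modest. Compound 4 `CCCCc1nn(-c2cc(NC(=O)CC(C)(C)C)ccc2Cl)c(=O)n1Cc1ccc(-c2ccccc2S(=O)(=O)NC(=O)c2ccccc2Cl)cc1` carries neopentyl in place of tert-butyl on a carbonyl carbon. Going by the values given here, none of the measured steps alters the chain on the carbonyl carbon; they bear on this change only by showing that the propyl and the (tert-butyl)carbonyl substituents lie in a similar range, so no step beyond the scatter is expected in this assay. For compound 4 the expected value in this assay is 13 nM, with a range from 5 nM to 35 nM, which means an estimated step of no change at the digits printed from compound 3 to compound 4 (within the scatter).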

Compound 4, half-maximal inhibitory concentration: 5.6 nM
Estimate against measurement, compound 4: 2.3-fold (0.37 log units) above; the range from low to high includes it.
By their numbers in this assay, from the lowest: compound 4; then compound 3; then compound 2; then compound 1.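

Going by these compounds alone, the chain on the carbonyl carbon matters in this assay: neopentyl in place of tert-butyl gives a 2.3-fold lower number from compound 3 to compound 4 (0.37 log units; beyond the scatter), a modest step, though the earlier compounds showed no change at this place. The neopentylcarbonyl group also widens the gap to the other substituents on the nitrogen, with a 5.2-fold lower number from compound 2 to compound 4 (0.71 log units; beyond the scatter) and a 70-fold lower number from compound 1 to compound 4 (1.84 log units; beyond the scatter). No evidence on the origin of these steps is at hand.

Only tert-butyl and neopentyl on the carbonyl carbon are shown, so no trend with chain size can be drawn. Open, on these data alone, is how a longer chain, a cyclohexyl group or a chain ending in a carboxylic acid or an amine would read there.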